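The source may report more compounds than this note shows. Statements on the series, on what has been measured and on what is new or still open speak of the compounds shown alone.

Of the compounds shown here, three have so far been measured in a functional assay on SGC-7901 cells (Homo sapiens) for cytotoxicity, read by MTT assay, with a stated time of 48 h; on this read-out lower numbers stand for stronger inhibition and higher numbers for weaker inhibition. Compound 1, `CC(C)=CCC/C(C)=C/CC/C(C)=C/CSc1ccccc1C(=O)NCC(=O)OCC#CCOc1no[n+]([O-])c1S(=O)(=O)c1ccccc1`, gives 11400 nM. Compound 2, `CC(C)=CCC/C(C)=C/CC/C(C)=C/CSc1ccccc1C(=O)N1CCC[C@H]1C(=O)OCCOCCOc1no[n+]([O-])c1S(=O)(=O)c1ccccc1`, gives 7860 nM. Compound 3, `CC(C)=CCC/C(C)=C/CC/C(C)=C/CSc1ccccc1C(=O)N1CCC[C@H]1C(=O)OC(C)CCOc1no[n+]([O-])c1S(=O)(=O)c1ccccc1`, gives 13900 nM. Among these three numbers compound 1 holds the second highest place; its nearest neighbour is compound 3, whose number lies within the usual scatter of repeated measurements of compound 1, and its furthest neighbour is compound 2, whose number also stays within that scatter. No two of the measured compounds differ from each other in only one place, so no single structural change has yet been tied to a movement in this assay; the three values show only that all of them lie close together.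

Compound 4, `CC(C)=CCC/C(C)=C/CC/C(C)=C/CSc1ccccc1C(=O)N[C@@H](C)C(=O)OCC#CCOc1no[n+]([O-])c1S(=O)(=O)c1ccccc1`, has not yet been measured. It differs from compound 1 by methyl in place of hydrogen on a saturated chain carbon bound to an amide-type nitrogen and a carbonyl carbon. For the measured compounds named here, there is no measured step of this kind to lean on, and nothing in the three values suggests that a change of one heavy atom would move the number beyond the scatter in this assay. Compound 4 is therefore expected to give about 10500 nM, with a range from 5000 nM to 22000 nM. The expected step, a 1.1-fold lower number from compound 1 to compound 4 (0.04 log units; within the scatter), amounts to no change beyond the scatter.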

Compound 4, half-maximal inhibitory concentration: 11400 nM
Estimate against measurement, compound 4: 1.1-fold (0.04 log units) below; the measured number falls inside the stated range.
By their numbers in this assay, from the lowest: compounds 2, 1, 4 and 3 (each within the scatter of the next).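

Putting methyl in place of hydrogen on a saturated chain carbon bound to an amide-type nitrogen and a carbonyl carbon gives no change at the digits printed from compound 1 to compound 4 (within the scatter) in this assay. For the compounds shown here, this is the first change in a single place that can be read, as the earlier compounds all differed from one another in more than one place, and it shows that this chain carbon can carry a methyl with no movement of the number beyond the usual scatter. No supporting measurement is available to explain this flat result, so the step records what happens at this position but not the reason for it.

As far as these compounds go, a single small group says little about larger or different ones, so it remains open whether a longer chain, a benzyl group, an amine or a carboxylic acid on this same carbon would also leave the number in place. Also open, from the compounds shown here alone, are whether the methyl's opposite spatial arrangement on this carbon would give a similar number and whether the same change would behave alike on a compound with a different linking chain.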